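Adding a chloro group to compound 2

This account rests on a few compounds, and the source may have more. Where it says the series, first, only, none or still open, it means among the compounds named here.

Values in a functional assay on Caco-2 cells (Homo sapiens) for antiproliferative activity, read by MTT assay; a higher number here means a weaker inhibitor, a lower number a stronger inhibitor:
- Compound 1 `NS(=O)(=O)c1ccc(/N=C2\NC(=O)/C(=C3/C(=O)N(Cc4ccccc4)c4ccc(Cl)cc43)S2)cc1`: 13700 nM
- Compound 2 `CN1C(=O)/C(=C2\S/C(=N/c3ccc(S(N)(=O)=O)cc3)NC2=O)c2ccccc21`: 163000 nM
- Compound 3 `NS(=O)(=O)c1ccc(/N=C2\NC(=O)/C(=C3/C(=O)Nc4ccccc43)S2)cc1`: > 200000 nM (a limit, not a number)

Of the two true numbers, compound 2 holds the higher, 163000 nM. Compound 4 `CN1C(=O)/C(=C2\S/C(=N/c3ccc(S(N)(=O)=O)cc3)NC2=O)c2cc(Cl)ccc21` is compound 2 with one change: chloro in place of hydrogen on an aromatic carbon. Among the compounds with values here, no measured step tests this change directly. Within the data shown here, the one step available, an at least 1.2-fold higher number from compound 2 to compound 3 (0.08 log units; that floor lies within the scatter), lies elsewhere in the molecule. Compound 1 also carries a chloro group and gives the lower 13700 nM, but it differs from compound 2 in more than this one place. A moderate drop in this assay is therefore expected, smaller than that whole gap. The expected change is a 2.3-fold lower number from compound 2 to compound 4 (0.37 log units; beyond the scatter). For compound 4 the estimated value is 70000 nM, with an expected range from 20000 nM to 170000 nM.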

Compound 4, half-maximal inhibitory concentration: 42300 nM
The estimate for compound 4 lay 1.7-fold (0.22 log units) above the measured number, and the stated range covers the measured number.
By their numbers in this assay, from the lowest: compound 1; then compound 4; then compound 2. At a limit, above all of these: compound 3.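

Within the data shown here, compound 4 gives the first direct reading of this position in this assay: chloro in place of hydrogen on the aromatic carbon brings a 3.9-fold lower number from compound 2 to compound 4 (0.59 log units; beyond the scatter) and so counts on its own. With the chloro group kept, the phenyl on the chain carbon bound to the ring nitrogen also counts, since hydrogen in its place brings a 3.1-fold higher number from compound 1 to compound 4 (0.49 log units; beyond the scatter) as a separate step. The gap between compound 1 and compound 2 thus splits into two modest steps.

From the compounds shown here alone, whether a fluoro, bromo or methoxy group at this position would act like chloro stays open. Nothing shown here bears on why the chloro group has this effect.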